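Removing the Ring Methyl from Compound 2

This account rests on a few compounds, and the source may have more. Where it says the series, first, only, none or still open, it means among the compounds named here.

Of the compounds shown here, three have been measured in a functional assay on SW480 cells (Homo sapiens) for inhibition, read by luminescence and resazurin assay, with a stated time of 3 days; a lower number here means a stronger inhibitor, a higher number a weaker inhibitor. Compound 1 `O=C(Nc1ccc(F)cc1)c1ccc(CNc2nc(NC3CC3)nc3ccccc23)cc1` gives 2600 nM. Compound 2 `C=CCNc1nc(NCc2ccc(C(=O)Nc3ccc(F)cc3)cc2)c2cc(C)ccc2n1` gives 10000 nM, the highest of the three numbers and therefore the weakest inhibitor among them, beyond the scatter against both others. Compound 3 `CCCNc1nc(NCc2ccc(C(=O)Nc3ccc(F)cc3)cc2)c2cc(C)ccc2n1` gives 1300 nM. Going by the values given here, the only single-place step among the measured compounds, a 7.7-fold lower number from compound 2 to compound 3 (0.89 log units; beyond the scatter), concerns the chain on the amine nitrogen and leaves the ring untouched.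

Compound 4 `C=CCNc1nc(NCc2ccc(C(=O)Nc3ccc(F)cc3)cc2)c2ccccc2n1` keeps the allyl chain of compound 2 and differs from it in one place: hydrogen in place of methyl on an aromatic carbon. Among the compounds with values here, no measured step alters this methyl alone. Compound 1 also lacks the methyl, but it carries a cyclopropyl group on the amine nitrogen instead of the allyl chain, so its value set against that of compound 2 mixes two changes and cannot be separated. With nothing bearing directly on the loss of a single methyl from the ring, the step expected from compound 2 to compound 4 is a 1.4-fold lower number from compound 2 to compound 4 (0.15 log units; within the scatter), which does not go beyond the scatter. Compound 4 is accordingly estimated at 7000 nM in this assay, within a range from 2500 nM to 20000 nM.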

Compound 4, half-maximal inhibitory concentration: 11000 nM
Estimate against measurement, compound 4: 1.6-fold (0.20 log units) below; low and high end bracket the measured number.
By their numbers in this assay, from the lowest: compounds 3 and 1 (each within the scatter of the next); then compounds 2 and 4 (each within the scatter of the next).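

In this assay the exchange of methyl for hydrogen on this aromatic carbon gives a 1.1-fold higher number from compound 2 to compound 4 (0.04 log units; within the scatter) and so the two allyl compounds cannot be told apart, which means that alongside an allyl chain this methyl makes no readable difference. Going by these compounds alone, compound 4 also provides the first comparison of chains on the core without the methyl, with a 4.2-fold higher number from compound 1 to compound 4 (0.63 log units; beyond the scatter) when allyl takes the place of cyclopropyl on the nitrogen, a step beyond the scatter. Among these four compounds, both single-place chain changes, this one and a 7.7-fold lower number from compound 2 to compound 3 (0.89 log units; beyond the scatter) on the core that keeps the methyl, lie beyond the scatter while the single change at the ring methyl does not, and nothing available here explains this difference.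

From the compounds shown here alone, it remains open whether the methyl would also make no readable difference alongside the propyl chain of compound 3 or the cyclopropyl group of compound 1. Going by these compounds, it is also open whether a larger group on the same aromatic carbon, such as methoxy or a chlorine atom, would give a number that differs from those seen with hydrogen and methyl.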